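Swapping a nitrile for an amide in a cytotoxic series

The source may report more compounds than this note shows. Statements on the series, on what has been measured and on what is new or still open speak of the compounds shown alone.

Of the compounds shown here, three sharing one core have been measured in a functional assay on Ehrlich cells (Mus musculus) for cytotoxicity, read by trypan blue exclusion, with a stated time of 2 h, tested at 50 ug/mL; a higher number here means a stronger effect of the compound at the concentration tested, a lower number a weaker effect. Compound 1 `N#CC1=C(N)N(c2ccc(S(N)(=O)=O)cc2)C2=C(C(=O)CCC2)C1c1ccc(Cl)cc1Cl` gives 65% and stands second highest of the three. Compound 3 `N#CC1=C(NC(=O)c2ccccc2)N(c2ccc(S(N)(=O)=O)cc2)C2=C(C(=O)CCC2)C1c1ccc(Cl)cc1Cl`, which carries a benzoyl in place of hydrogen on the amine nitrogen, gives 70%; the step of a number 5 percentage points higher from compound 1 to compound 3 (within the scatter) lies within the scatter. Among the compounds with values here, compound 2 `N#CC1=C(NC(=O)C2CC2)N(c2ccc(S(N)(=O)=O)cc2)C2=C(C(=O)CCC2)C1c1ccc(Cl)cc1Cl`, with a cyclopropylcarbonyl on that amine nitrogen, gives 40%, and the step of a number 25 percentage points lower from compound 1 to compound 2 (beyond the scatter) is the only step from compound 1 that reaches beyond the scatter. Compound 4 `NC(=O)C1=C(N)N(c2ccc(S(N)(=O)=O)cc2)C2=C(C(=O)CCC2)C1c1ccc(Cl)cc1Cl` is not yet measured and differs from compound 1 at another position: carbamoyl in place of cyano on a double-bonded ring carbon. Within the data shown here, no measured step touches the cyano group or the double-bonded ring carbon that carries it, so none bears directly on this change; the measured steps concern only the amine nitrogen, and they ran in both directions. With no direct guide, the expected step of a number 5 percentage points lower from compound 1 to compound 4 (within the scatter) is none beyond the scatter. Compound 4 is therefore estimated at 60%, with a range from 40% to 80%.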

Compound 4, a percentage reported as activity, at one concentration (the size of the read-out at that concentration, not a potency): 40%
Beside the measured number, compound 4's estimate is 20 percentage points above it; low and high end bracket the measured number.
By their numbers in this assay, from the lowest: compounds 2 and 4 (each within the scatter of the next); then compounds 1 and 3 (each within the scatter of the next).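

In this assay, carbamoyl in place of cyano on the double-bonded ring carbon gives a number 25 percentage points lower from compound 1 to compound 4 (beyond the scatter). Within the data shown here, the earlier steps all concerned the amine nitrogen, so this is the first sign that the number also responds to a change at this second position, and the step goes beyond the scatter. Nothing at hand gives a reason for the fall.

From the compounds shown here alone, it remains open whether other groups on this carbon, such as a carboxylic acid or a methyl ester, would give a number closer to that of the cyano compound or of the carbamoyl compound. Going by these compounds, the steps at the amine nitrogen are known only with cyano present, so it is also open whether a benzoyl or cyclopropylcarbonyl there would act the same way alongside carbamoyl.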